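Swapping the Carbamate Cap on a Dithiocarbamate Piperazine

The compounds below may be only part of what the source reports. "The series", "measured", "known", "first", "only" and "open" are said of these compounds alone.

Three compounds share a core in which a triazole carries a methylene-linked dithiocarbamate attached to a piperazine ring. Compound 1 `CC(C)(C)OC(=O)N1CCN(C(=S)SCc2cn(-c3ccccc3F)nn2)CC1` caps the piperazine with a tert-butoxycarbonyl group and carries a fluorophenyl on the triazole. In a functional assay on MCF7 cells (Homo sapiens) for inhibition, read by MTT assay, with a stated time of 72 h (a higher number here means a weaker inhibitor, a lower number a stronger inhibitor), compound 1 gives 89600 nM. Compound 2 `COc1ccc(Cn2cc(CSC(=S)N3CCNCC3)nn2)cc1` has the piperazine left uncapped; in this assay compound 2 gives "not determined" (no result reported). Compound 3 `COc1ccc(Cn2cc(CSC(=S)N3CCN(C(=O)OCc4ccccc4)CC3)nn2)cc1` carries a methoxybenzyl on the triazole and a benzyloxycarbonyl cap on the piperazine. In this assay compound 3 gives 30500 nM, the lowest of the two numbers that exist, with compound 1 standing beyond the usual scatter above it.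

Compound 4 `COc1ccc(Cn2cc(CSC(=S)N3CCN(C(=O)OC(C)(C)C)CC3)nn2)cc1` keeps the methoxybenzyl-triazole side of compound 3 and changes only the cap: tert-butyl in place of benzyl on an oxygen next to a carbonyl group. Among the measured compounds shown here, no measured pair differs in this one place alone, so the size of the step is uncertain. The tert-butoxycarbonyl group appears in compound 1, whose weaker value 89600 nM also reflects its different triazole substituent, so that comparison is only a loose hint.

Compound 4 is therefore expected to lose a little, with the step of a 1.6-fold higher number from compound 3 to compound 4 (0.21 log units; within the scatter) estimated to be modest. The estimate for compound 4 in this assay is 50000 nM, within 20000 nM to 120000 nM.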

Compound 4, half-maximal inhibitory concentration: 4960 nM
Beside the measured number, compound 4's estimate is 10-fold (1.00 log units) above it, outside the stated range (below it).
By their numbers in this assay, from the lowest: compound 4; then compound 3; then compound 1.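

In this assay, among the compounds shown here, the cap on the piperazine matters far more than the earlier compounds could show: tert-butyl in place of benzyl on an oxygen next to a carbonyl group gives a 6.1-fold lower number from compound 3 to compound 4 (0.79 log units; beyond the scatter) and is beyond the usual scatter, so on this core the cap without a ring is clearly the better of the two. The other end of the molecule also counts, since with the tert-butoxycarbonyl cap held fixed, 4-methoxybenzyl in place of 2-fluorophenyl on an aromatic nitrogen gives an 18-fold lower number from compound 1 to compound 4 (1.26 log units; beyond the scatter), the larger of the two steps. The data shown offer no measurement that explains either step.

On these data alone, it remains open whether the gain follows the branched shape of tert-butyl or simply the loss of the benzyl ring, a question that an isopropyl or a cyclohexyl cap on the same oxygen would help to settle. Also open, as far as these compounds go, is whether the step on the aromatic nitrogen holds under the benzyloxycarbonyl cap, and whether a simple acetyl group in place of the whole carbamate would keep the strength of compound 4.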